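Carbonyl aryl variation on a furyl-bearing core: step to naphthyl

This account rests on a few compounds, and the source may have more. Where it says the series, first, only, none or still open, it means among the compounds named here.

Measured so far in a functional assay on PC-3 cells (Homo sapiens) for cytotoxicity, read by MTT assay, with a stated time of 48 h; a lower number here means a stronger inhibitor, a higher number a weaker inhibitor:
- compound 1, `COc1cc(-c2nnc3n2NC(c2ccco2)C(C(=O)c2ccc(-c4ccccc4)cc2)S3)cc(OC)c1OC`, gives 45900 nM
- compound 2, `COc1cc(-c2nnc3n2NC(c2ccco2)C(C(=O)c2ccccc2C)S3)cc(OC)c1OC`, gives 88400 nM
- compound 3, `COc1cccc(C(=O)C2Sc3nnc(-c4cc(OC)c(OC)c(OC)c4)n3NC2c2ccco2)c1`, gives 84600 nM

All three share one core and differ only in the aryl group on the carbonyl carbon. Compound 3 stands second highest of the three numbers; its nearest neighbour is compound 2, and the distance to compound 1 is also within the scatter. Within the data shown here, none of the measured steps, a 1.9-fold higher number from compound 1 to compound 2 (0.28 log units; within the scatter), a 1.8-fold higher number from compound 1 to compound 3 (0.27 log units; within the scatter) and a 1.0-fold lower number from compound 2 to compound 3 (0.02 log units; within the scatter), rises beyond the scatter, so the aryl on the carbonyl carbon has so far not moved this assay in a way that can be told from noise.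

Compound 4, `COc1cc(-c2nnc3n2NC(c2ccco2)C(C(=O)c2cccc4ccccc24)S3)cc(OC)c1OC`, continues this series with the change (naphthalen-1-yl in place of 3-methoxyphenyl on a carbonyl carbon). Among the measured compounds shown here, the only comparison that bears on it is the step between compound 1 and compound 3, where a larger aryl group went with a slightly lower number, still within the scatter. The step from compound 3 to compound 4 is therefore expected to stay within the scatter, a 1.3-fold lower number from compound 3 to compound 4 (0.11 log units; within the scatter), with no clear direction. Compound 4 is expected to give about 65000 nM in this assay, between 25000 nM and 160000 nM.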

Compound 4, half-maximal inhibitory concentration: > 100000 nM
Compound 4 gave a limit, no number; the forecaster's own chance of this, stated with the estimate: 10%; middle value at least 1.5-fold (0.18 log units) away from the limit.
By their numbers in this assay, from the lowest: compounds 1, 3 and 2 (each within the scatter of the next). At a limit, above all of these: compound 4.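

In this assay compound 4 stands as a limit of the assay and not as a number: the limit of > 100000 nM in this assay, at which 1 of the 4 values shown sits.
Among these compounds, this gives the first step at the aryl on the carbonyl carbon that lies beyond the scatter (an at least 2.1-fold higher number from compound 1 to compound 4 (0.33 log units; beyond the scatter)), so naphthalen-1-yl and 4-phenylphenyl can be told apart at this position, although both are larger than 3-methoxyphenyl, and a larger aryl alone therefore gives no single direction. The other two steps (an at least 1.1-fold higher number from compound 3 to compound 4 (0.07 log units; that floor lies within the scatter)) and (an at least 1.1-fold higher number from compound 2 to compound 4 (0.05 log units; that floor lies within the scatter)) have floors within the scatter, so naphthalen-1-yl is not yet separated from 3-methoxyphenyl or 2-methylphenyl.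

On these data alone, how far compound 4 lies past its limit remains open. Also open, as far as these compounds go, are whether naphthalen-2-yl behaves like naphthalen-1-yl and what an amine or a carboxylic acid on the aryl would do.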